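Replacing an amide with a chlorinated aryl ketone

This account rests on a few compounds, and the source may have more. Where it says the series, first, only, none or still open, it means among the compounds named here.

Measured compounds:
compound 1, `COC(=O)/C(=C\c1c(-c2ccccc2)[nH]c2ccccc12)S(=O)(=O)c1ccccc1`: 1000 nM
compound 2, `N#C/C(=C\c1c(-c2ccccc2)[nH]c2ccccc12)C(N)=O`: 6000 nM
compound 3, `CC(=O)/C(=C/c1c(-c2ccccc2)[nH]c2ccccc12)C(=O)c1ccccc1`: 2000 nM

Of the compounds shown here, three on a shared core have been tested in a functional assay on MT4 cells (Homo sapiens) for antiproliferative activity, read by MTT assay, with a stated time of 96 h; on this read-out lower numbers stand for an effect already at smaller amounts and higher numbers for an effect only at larger amounts of compound. Compound 2 gives 6000 nM, the highest of the three numbers. Compound 3 is nearest with 2000 nM, and compound 1 furthest with 1000 nM; both gaps lie beyond the usual scatter, so compound 2 is the weakest of the set.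

Compound 4, `N#C/C(=C\c1c(-c2ccccc2)[nH]c2ccccc12)C(=O)c1ccc(Cl)cc1`, alters compound 2 at one spot: 4-chlorophenyl in place of amino on a carbonyl carbon. Within the data shown here, no measured pair shows this exact change, so the direction of the step must be inferred from the set. Since both other compounds give lower numbers than compound 2, the step is expected to go downward, beyond the scatter, by a 3.0-fold lower number from compound 2 to compound 4 (0.48 log units; beyond the scatter). Compound 4 is therefore expected to give about 2000 nM, within 500 nM to 8000 nM.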

Compound 4, half-maximal effective concentration: 400 nM
Beside the measured number, compound 4's estimate is 5.0-fold (0.70 log units) above it; the whole stated range lies above it.
By their numbers in this assay, from the lowest: compound 4; then compounds 1 and 3 (each within the scatter of the next); then compound 2.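

In this assay, among these compounds, putting 4-chlorophenyl in place of amino on the carbonyl carbon gives a 15-fold lower number from compound 2 to compound 4 (1.18 log units; beyond the scatter) and is the only step here that changes one place alone. It shows that this position accepts a far larger group, one with a six-membered aromatic ring and no hydrogen-bond donor, and that the number drops sharply with it. No measured evidence here explains the drop. On these data alone, whether the chlorine or the ring itself carries the step stays open. A cyclohexyl or 4-methoxyphenyl group on the same carbonyl carbon would help to separate the two.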